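This account rests on a few compounds, and the source may have more. Where it says the series, first, only, none or still open, it means among the compounds named here.

In a functional assay on MCF7 cells (Homo sapiens) for inhibition, read by MTT assay, with a stated time of 48 h, tested at 10 uM (on this read-out higher numbers stand for more inhibition of growth at the one concentration tested and lower numbers for less inhibition of growth), compound 2 `COc1ccc(C(=O)/C=C/c2ccc(OCc3cn(Cc4ccccc4)nn3)cc2)cc1` gives 70%, and compound 3 `COc1ccc(C(=O)/C=C/c2ccc(OCc3cn(Cc4ccccc4Br)nn3)cc2)cc1` gives 60%. Compound 1 `O=C(/C=C/c1ccc(OCc2cn(Cc3cccc(Br)c3)nn2)cc1)c1ccc(Br)cc1` gives 36% in this assay. Compound 3 thus stands second highest of the three: its nearest neighbour is compound 2, within the scatter, while compound 1 lies beyond the scatter below it. Compound 4 `COc1ccc(C(=O)/C=C/c2ccc(OCc3cn(Cc4cccc(Br)c4)nn3)cc2)cc1` carries 3-bromophenyl in place of 2-bromophenyl on a saturated chain carbon bound to an aromatic nitrogen. For the measured compounds named here, the only measured step that bears on this is a number 10 percentage points lower from compound 2 to compound 3 (within the scatter), a change within the scatter. Compound 1 and compound 3 also differ elsewhere in the molecule, so their gap cannot be tied to the bromine alone. With one small comparison to go on, the expected step is a number 2 percentage points lower from compound 3 to compound 4 (within the scatter), no move beyond the scatter. Compound 4 is therefore estimated at 58%, with a range from 40% to 72%.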

Compound 4, percent growth inhibition at one concentration: 45%
Compound 4: the middle estimate sits 13 percentage points above what was measured, within the range that was stated.
By their numbers in this assay, from the lowest: compounds 1 and 4 (each within the scatter of the next); then compounds 3 and 2 (each within the scatter of the next).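

In this assay, the same atoms joined differently, 3-bromophenyl in place of 2-bromophenyl, give a number 15 percentage points lower from compound 3 to compound 4 (beyond the scatter), so in this pair the place of the bromine on the ring counts, which the earlier step within the scatter could not show. Adding the bromine as 3-bromophenyl gives a number 25 percentage points lower from compound 2 to compound 4 (beyond the scatter), whereas methoxy in place of bromo on the other aromatic ring gives a number 9 percentage points higher from compound 1 to compound 4 (within the scatter). No measurement at hand explains these steps.

From the compounds shown here alone, whether a fluoro or an amine in place of bromo on 3-bromophenyl would behave the same way remains open.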